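Chloromethyl in place of a three-atom group: two pairs

A few compounds are considered here, and "the series" means these few. Any claim that something is new, unique, unknown or untested is made for them only; others in the source may bear on it.

The series is read in a functional assay on MOLT-3 cells (Homo sapiens); a lower number here means a stronger inhibitor, a higher number a weaker inhibitor. Compound 1 `CC(=O)N[C@@H](CSC/C=C(\C)CCC=C(C)C)C(=O)C=[N+]=[N-]` carries on its carbonyl carbon a group of 3 heavy atoms (1 carbon, 2 nitrogen). In this assay compound 1 gives > 100000 nM, which is a limit of the assay and not a number. Compound 2 `CC(=O)N[C@@H](CSC/C=C(\C)CCC=C(C)C)C(=O)CCl` differs from compound 1 by a group of 2 heavy atoms (1 carbon, 1 chlorine; no ring) in place of a group of 3 heavy atoms (1 carbon, 2 nitrogen; no ring), on a carbonyl carbon. In this assay compound 2 gives > 100000 nM, again a limit rather than a number. The step that the two limits leave unreadable from compound 1 to compound 2 therefore cannot be read, and its two values show only that both sit at the same limit, as noted in the limit of > 100000 nM in this assay, at which 2 of the 3 values shown sit.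

Compound 3 `CC(C)=CCC/C(C)=C/CC/C(C)=C/CSC[C@H](NC(=O)CNC(=O)OC(C)(C)C)C(=O)C=[N+]=[N-]` has a larger core; how it differs from compound 1 is not broken down here. In this assay, among the measured compounds shown here, compound 3 gives 84500 nM, the only number in the set. Compound 4 `CC(C)=CCC/C(C)=C/CC/C(C)=C/CSC[C@H](NC(=O)CNC(=O)OC(C)(C)C)C(=O)CCl` differs from compound 3 by a group of 2 heavy atoms (1 carbon, 1 chlorine; no ring) in place of a group of 3 heavy atoms (1 carbon, 2 nitrogen; no ring), on a carbonyl carbon, the same change as that from compound 1 to compound 2, made on the same kind of carbonyl carbon with a saturated chain carbon as its other neighbour.

Since the first pair leaves the size of the change unreadable, the expectation for compound 4 rests on compound 3 and its value 84500 nM alone, with the step estimated as a 1.4-fold higher number from compound 3 to compound 4 (0.15 log units; within the scatter). Compound 4 is expected to give about 120000 nM in this assay, with a likely range from 40000 nM to 400000 nM, and a real chance that only a limit is reported.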

Compound 4, half-maximal inhibitory concentration: 17500 nM
The estimate for compound 4 lay 6.9-fold (0.84 log units) above the measured number; the whole stated range lies above it.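

In this assay, among the compounds shown here, on the core of compound 3, chloromethyl in place of the three-atom group gives a 4.8-fold lower number from compound 3 to compound 4 (0.68 log units; beyond the scatter), a step beyond the usual scatter and the only readable instance of this change. The same change on the core of compound 1 cannot be read, as compound 1 and compound 2 each stand at a limit of the assay and not at a number: the limit of > 100000 nM in this assay, at which 2 of the 4 values shown sit. The series therefore shows that the change can lower the number on one core, but a single readable pair does not show that the step carries to the other core, or that its size would be the same there.

The cores of compound 1 and compound 3 differ in more than one place, leaving open which part of the core decides whether a number can be read at all, for instance the chain on the sulfur or the group on the amide nitrogen. Also open, going by these compounds, is how the step would look with a bromomethyl group or a carboxylic acid in place of chloromethyl on the same carbonyl carbon, or with a longer chain on the sulfur.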